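A few compounds are considered here, and "the series" means these few. Any claim that something is new, unique, unknown or untested is made for them only; others in the source may bear on it.

In a functional assay on MDA-MB-231 cells (Homo sapiens) for antiproliferative activity, read by MTT assay, with a stated time of 24 h (a higher number here means a weaker inhibitor, a lower number a stronger inhibitor), compound 1 `Cc1ccccc1NNC(=O)c1cccc(NS(=O)(=O)c2cnc(O)nc2O)c1` gives > 20000 nM, which is a limit of the assay and not a number. This places compound 1 at the limit of > 20000 nM in this assay, at which 1 of the 2 values shown sits, so its true position is not pinned down. Among the compounds with values here, the only exact reading comes from compound 2 `O=C(NNc1cccc(Cl)c1)c1ccccc1NS(=O)(=O)c1cnc(O)nc1O`, which gives 11800 nM. Compound 2 differs from compound 1 in more than one place, so it offers no clean one-change comparison.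

Compound 3 `Cc1ccccc1C(=O)NNC(=O)c1cccc(NS(=O)(=O)c2cnc(O)nc2O)c1` is built from compound 1 with a single change: (2-methylphenyl)carbonyl in place of 2-methylphenyl on an amine nitrogen. The same difference, cut one bond further out, reads (2-methylphenyl)amino to ((2-methylphenyl)carbonyl)amino.

Within the data shown here, no measured step shows what this change does in this assay. The starting point is compound 1, with its limit of > 20000 nM, so compound 3 is expected to remain a weak inhibitor, with no shift beyond the usual scatter in either direction. The expected change is a step that the limit leaves unreadable from compound 1 to compound 3. For compound 3 the estimated value is 22000 nM, with an expected range from 11000 nM to 45000 nM.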

Compound 3, half-maximal inhibitory concentration: 18100 nM
The estimate for compound 3 lay 1.2-fold (0.08 log units) above the measured number, and the stated range covers the measured number.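

In this assay compound 1 gives > 20000 nM, which is a limit of the assay and not a number. With (2-methylphenyl)carbonyl in place of 2-methylphenyl on the amine nitrogen, compound 3 gives an exact reading of 18100 nM, so this position now has a firm value in the series, and it shows that this larger group, with its added carbonyl, still leaves a weak inhibitor. The change can be read only as a floor, an at least 1.1-fold lower number from compound 1 to compound 3 (0.04 log units; that floor lies within the scatter), so whether it truly moves the number, and by how much, stays hidden: the limit of > 20000 nM in this assay, at which 1 of the 3 values shown sits.

The compounds shown leave open whether the carbonyl or the 2-methylphenyl ring matters more here, a question that a plain acetyl group or an unsubstituted phenylcarbonyl at this place could help to separate. They also leave open what quite different groups on this amine nitrogen, such as a longer alkyl chain or a chain ending in a carboxylic acid, would do to the reading in this assay.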